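Swapping the aryl group on the hydrazone carbon

The source may report more compounds than this note shows. Statements on the series, on what has been measured and on what is new or still open speak of the compounds shown alone.

Measured so far:
Compound 1 `COc1ccc(/C=N/NC(=O)c2ccc(-c3nc4ccccc4s3)cc2)c(O)c1`: in an assay on isolated protein for inhibition of Maltase-glucoamylase (Homo sapiens), with a stated time of 15 min (on this read-out higher numbers stand for weaker inhibition and lower numbers for stronger inhibition), compound 1 gives 6970 nM.
Compound 2 `O=C(N/N=C/c1ccc([N+](=O)[O-])cc1)c1ccc(-c2nc3ccccc3s2)cc1`: in this assay compound 2 gives 26400 nM.

Both compounds share the same core; they differ only in the aryl group attached to the carbon with a double bond to nitrogen. Among the compounds with values here, compound 2 stands at the higher of the two numbers, that is, it is the weaker inhibitor of the pair, and the only step available, a 3.8-fold higher number from compound 1 to compound 2 (0.58 log units; beyond the scatter), shows that replacing the 2-hydroxy-4-methoxyphenyl of compound 1 with 4-nitrophenyl pushed the number up.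

Compound 3 `COc1cc(/C=N/NC(=O)c2ccc(-c3nc4ccccc4s3)cc2)cc(OC)c1` has not yet been measured. It arises from compound 2 by 3,5-dimethoxyphenyl in place of 4-nitrophenyl on a carbon with a double bond to nitrogen. Within the data shown here, with only one measured step to draw on, this change can be read as reversing the direction of that step: methoxy-bearing aryl returns, nitro leaves. Among the measured compounds shown here, compound 3 is therefore expected to give a lower number than compound 2, with a 2.4-fold lower number from compound 2 to compound 3 (0.38 log units; beyond the scatter) as the estimated step, though the size of that step is uncertain since no compound with two methoxy groups has been measured. The estimate for compound 3 in this assay is 11000 nM, with a range from 4000 nM to 30000 nM.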

Compound 3, half-maximal inhibitory concentration: 16200 nM
Estimate against measurement, compound 3: 1.5-fold (0.17 log units) below; low and high end bracket the measured number.
By their numbers in this assay, from the lowest: compound 1; then compounds 3 and 2 (each within the scatter of the next).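

In this assay, exchanging 4-nitrophenyl for 3,5-dimethoxyphenyl on the carbon with a double bond to nitrogen gives a 1.6-fold lower number from compound 2 to compound 3 (0.21 log units; within the scatter), so compounds 2 and 3 cannot be told apart here even though their aryl groups carry quite different substituents. The other new comparison, with 3,5-dimethoxyphenyl in place of 2-hydroxy-4-methoxyphenyl, gives a 2.3-fold higher number from compound 1 to compound 3 (0.37 log units; beyond the scatter), which leaves compound 1 as the strongest inhibitor of the three and shows that having methoxy groups on the aryl ring does not by itself bring the number back to that of compound 1. Nothing available here accounts for these differences.

Within the data shown here, compound 1 differs from compound 3 in both the kind and the arrangement of its substituents, so these three compounds cannot show whether its hydroxy group, its single methoxy group or the pattern of the two goes with its lower number. Going by these compounds, it also remains open how this position would respond to an aryl ring carrying only a hydroxy group, or to one carrying an amine or a carboxylic acid.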